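This account rests on a few compounds, and the source may have more. Where it says the series, first, only, none or still open, it means among the compounds named here.

Of the compounds shown here, three sharing a common core have so far been measured in an assay for inhibition of serine/threonine-protein kinase Sgk1 (Homo sapiens), with stated times of 30 min and 60 min, in the presence of a further agent that is not named here; on this read-out higher numbers stand for weaker inhibition and lower numbers for stronger inhibition. Compound 1 `Cc1n[nH]c2nc(-c3ccc(NS(=O)(=O)c4cc(Cl)ccc4F)cc3)nc(OCCC(=O)N(C)C)c12` gives 15 nM, compound 2 `Cc1n[nH]c2nc(-c3ccc(NS(=O)(=O)c4cc(Cl)ccc4F)cc3)nc(OCC(CO)CO)c12` gives 1 nM, and compound 3 `Cc1n[nH]c2nc(-c3ccc(NS(=O)(=O)c4cc(Cl)ccc4F)cc3)nc(OC3CCOCC3)c12` gives 5 nM. Among these three, compound 3 stands second highest: its nearest neighbour is compound 1, with a 3.0-fold lower number from compound 1 to compound 3 (0.48 log units; beyond the scatter), and its furthest is compound 2, with a 5.0-fold higher number from compound 2 to compound 3 (0.70 log units; beyond the scatter).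

Compound 4 `Cc1n[nH]c2nc(-c3ccc(NS(=O)(=O)c4cc(Cl)ccc4F)cc3)nc(OCCCO)c12` is not yet measured. It differs from compound 3 in one place: 3-hydroxypropyl in place of oxan-4-yl on an oxygen on an aromatic ring.

Within the data shown here, two measured steps bear on this change. The step of a 5.0-fold higher number from compound 2 to compound 3 (0.70 log units; beyond the scatter) shows that a hydroxyl-bearing open chain on that oxygen gave a lower number than the oxan-4-yl ring, and the step of a 3.0-fold lower number from compound 1 to compound 3 (0.48 log units; beyond the scatter) shows that the ring itself sat below an amide-bearing chain. Compound 4 carries a single hydroxyl rather than the two of compound 2, so a step in this assay smaller than a 5.0-fold higher number from compound 2 to compound 3 (0.70 log units; beyond the scatter) but in the lowering direction is expected, about a 2.0-fold lower number from compound 3 to compound 4 (0.30 log units; within the scatter). Compound 4 is therefore estimated at 2.5 nM, within 1 nM to 8 nM.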

Compound 4, half-maximal inhibitory concentration: 2 nM
Estimate against measurement, compound 4: 1.3-fold (0.10 log units) above; measured number inside the range.
By their numbers in this assay, from the lowest: compounds 2 and 4 (each within the scatter of the next); then compound 3; then compound 1.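

In this assay, the change from oxan-4-yl to 3-hydroxypropyl gives a 2.5-fold lower number from compound 3 to compound 4 (0.40 log units; beyond the scatter), so at this position an open chain carrying a single hydroxyl already lowers the number, and compound 2's second hydroxymethyl is not needed for that. Indeed, hydrogen in place of that hydroxymethyl gives only a 2.0-fold higher number from compound 2 to compound 4 (0.30 log units; within the scatter), so this assay cannot separate the one-hydroxyl chain from the branched two-hydroxyl chain. Hydroxymethyl in place of dimethylcarbamoyl gives a 7.5-fold lower number from compound 1 to compound 4 (0.88 log units; beyond the scatter), which sets the amide-bearing chain of compound 1 clearly apart from the hydroxyl-bearing chain of compound 4.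

Nothing available gives a reason for these steps. On these data alone, it remains open whether a longer chain ending in hydroxyl, a methyl ether of that hydroxyl, an amine or a carboxylic acid on this oxygen would hold the number of compound 4.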